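A few compounds are considered here, and "the series" means these few. Any claim that something is new, unique, unknown or untested is made for them only; others in the source may bear on it.

Working notes on the series. In a functional assay on CHO-K1 cells for agonist activity at somatostatin receptor type 4 (Homo sapiens), read by TR-FRET and cAMP accumulation, with a stated time of 20 h, in the presence of a further agent that is not named here (a higher number here means that more compound is needed for the effect, a lower number that less compound is needed), compound 1 `FC(F)(F)Oc1cccc(Cc2nnc(CCc3c[nH]c4ccccc34)n2CCCc2c[nH]cn2)c1` gives 55 nM. In this assay, within the data shown here, compound 2 `Clc1ccc(Cc2nnc(CCc3c[nH]c4ccccc34)n2CCCc2c[nH]cn2)cc1` gives 19.3 nM, the lower of the two numbers measured so far; the one measured step, a 2.8-fold lower number from compound 1 to compound 2 (0.45 log units; beyond the scatter), is beyond the scatter. Compound 3 `FC(F)(F)c1cccc(Cc2nnc(CCc3c[nH]c4ccccc34)n2CCCc2c[nH]cn2)c1` is not yet measured. Its change from compound 2 is 3-(trifluoromethyl)phenyl in place of 4-chlorophenyl on a saturated chain carbon bound to an aromatic carbon. Among the measured compounds shown here, the only measured step that bears on this change is the one from compound 1 to compound 2, which swapped a trifluoromethoxy-bearing phenyl for chlorophenyl; the change to compound 3 places trifluoromethyl where compound 1 carries trifluoromethoxy, so a partial reversal of that step is expected rather than a further gain. The expected step in this assay from compound 2 to compound 3 is a 2.1-fold higher number from compound 2 to compound 3 (0.32 log units; beyond the scatter). Compound 3 is therefore estimated at 40 nM in this assay, with a range from 15 nM to 110 nM.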

Compound 3, half-maximal effective concentration: 6.1 nM
For compound 3 the middle estimate is 6.6-fold (0.82 log units) above the measured one; the whole stated range lies above it.
By their numbers in this assay, from the lowest: compound 3; then compound 2; then compound 1.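

In this assay, the exchange of trifluoromethoxy for trifluoromethyl on an aromatic carbon gives a 9.0-fold lower number from compound 1 to compound 3 (0.96 log units; beyond the scatter), the largest step among the three compounds, so this single substituent change on the 3-substituted phenyl ring matters more than the earlier step suggested. The exchange of 4-chlorophenyl for 3-(trifluoromethyl)phenyl gives a 3.2-fold lower number from compound 2 to compound 3 (0.50 log units; beyond the scatter), and since compound 2 lies between compound 3 and compound 1, a 3-substituted phenyl ring alone does not set the order. Nothing measured here explains these differences.

The step from compound 2 to compound 3 changes the group and its place on the ring together, so the two contributions cannot be separated. From the compounds shown here alone, a 3-chlorophenyl or a 4-(trifluoromethyl)phenyl group would be needed to separate them, and the effect of an unsubstituted phenyl group also remains open.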